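The source may report more compounds than this note shows. Statements on the series, on what has been measured and on what is new or still open speak of the compounds shown alone.

Compound 1, `COc1cc2c(cc1OC)C(CC(=O)N(C)C)CC2`, was tested in a functional assay on the whole organism (strain Wistar) for inhibition, with Rattus norvegicus as the target, read by paw edema, with stated times of 60 min and 4 h, at a dose of 100 mg/kg by the oral route (a higher number here means more inhibition at the dose given (going by the name of the read-out), a lower number less inhibition), where compound 1 gave 35.9%. Among the compounds with values here, its only measured companion is compound 2, `CCN(CC)C(=O)CC1CCc2cc(OC)c(OC)cc21`, and in this assay compound 2 gave 37.5%. Within the data shown here, the single step between them, a number 1.6 percentage points higher from compound 1 to compound 2 (within the scatter), sits within the scatter, so compound 1 stands at the lower of two numbers that are not separable from one another.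

Compound 3, `CCCCNC(=O)CC1CCc2cc(OC)c(OC)cc21`, has not been measured. It differs from compound 1 by butylamino in place of dimethylamino on a carbonyl carbon. Among the measured compounds shown here, the one step that bears on this change is the step from compound 1 to compound 2, which also altered the group on the same carbonyl carbon and moved the number by an amount within the scatter. On that basis no shift beyond the scatter is expected in this assay, and the step of a number 1.1 percentage points higher from compound 1 to compound 3 (within the scatter) is estimated to be small. Compound 3 is therefore expected to give about 37% in this assay, with a range from 24% to 50%.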

Compound 3, a percentage reported as inhibition, in the whole organism at one dose (the size of the read-out at that dose, not a potency): 25%
For compound 3 the middle estimate is 12 percentage points above the measured one, and the stated range covers the measured number.
By their numbers in this assay, from the lowest: compound 3; then compounds 1 and 2 (each within the scatter of the next).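

In this assay, the group on the carbonyl carbon proved able to move the number beyond the scatter: butylamino gave (a number 10.9 percentage points lower from compound 1 to compound 3 (beyond the scatter)) and, against diethylamino, (a number 12.5 percentage points lower from compound 2 to compound 3 (beyond the scatter)), whereas the earlier exchange of dimethylamino for diethylamino had stayed within it (a number 1.6 percentage points higher from compound 1 to compound 2 (within the scatter)). The group at this position is therefore not interchangeable, although this rests on a single butylamino compound, and the change from dimethylamino to butylamino alters two things at once: the group grows from 3 to 5 heavy atoms and gains a hydrogen-bond donor, so the amide hydrogen and the longer chain arrive together and cannot be told apart here. Nothing available explains the lower number.

The compounds shown leave open whether the amide hydrogen or the chain goes with the lower number: dibutylamino would keep butyl chains without that hydrogen, while methylamino would keep the hydrogen on a much shorter chain. They also leave open how a cyclic amine such as piperidine would behave on the same carbonyl carbon.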